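Fluoro for chloro: compound 2 to compound 3

The compounds below may be only part of what the source reports. "The series", "measured", "known", "first", "only" and "open" are said of these compounds alone.

Compound 2 `CN1CCC(=C(F)c2cccc(NC(=O)c3ccc(Cl)cc3)n2)CC1` gives 29.4 nM in a functional assay on HEK293 cells for agonist activity at 5-hydroxytryptamine receptor 1F (Homo sapiens), read by FLIPR, with a stated time of 60 min (on this read-out lower numbers stand for stronger inhibition and higher numbers for weaker inhibition), and compound 1 `CN1CCC(=C(F)c2cccc(NC(=O)c3ccc(F)cn3)n2)CC1` gives 24.3 nM. Compound 2 sits at the top of the two numbers, yet a 1.2-fold higher number from compound 1 to compound 2 (0.08 log units; within the scatter) is within the scatter, so nothing separates them. Compound 3 `CN1CCC(=C(F)c2cccc(NC(=O)c3ccc(F)cc3)n2)CC1` differs from compound 2 by fluoro in place of chloro on an aromatic carbon. For the measured compounds named here, no measured step exchanges one halogen for another on the 4-chlorophenyl; the single step known, a 1.2-fold higher number from compound 1 to compound 2 (0.08 log units; within the scatter), replaced the whole ring and stayed within the scatter. A step of a 1.2-fold lower number from compound 2 to compound 3 (0.07 log units; within the scatter) within the scatter is therefore expected for compound 3. Compound 3 is estimated at 25 nM, between 12 nM and 50 nM.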

Compound 3, half-maximal inhibitory concentration: 6.36 nM
The estimate for compound 3 lay 3.9-fold (0.59 log units) above the measured number; measured number outside the range, below it.
By their numbers in this assay, from the lowest: compound 3; then compounds 1 and 2 (each within the scatter of the next).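

In this assay, fluoro in place of chloro on the aromatic carbon is a one-atom exchange that gives a 4.6-fold lower number from compound 2 to compound 3 (0.66 log units; beyond the scatter), so this position responds to the identity of the halogen. The ring exchange also now reads beyond the scatter, with a 3.8-fold lower number from compound 1 to compound 3 (0.58 log units; beyond the scatter), once the 4-fluorophenyl group carries the fluoro. Nothing available gives a reason for either step.

Open, going by these compounds, is where a bromo, methoxy or nitrile group at this place would fall relative to fluoro and chloro. Also open, on these data alone, is how an unsubstituted phenyl ring would read.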